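Compound 3 to compound 4: hydroxy to methoxy

The source may report more compounds than this note shows. Statements on the series, on what has been measured and on what is new or still open speak of the compounds shown alone.

In an ADME assay on a cell-free system (plasma, Rattus norvegicus) for metabolic stability, read by LC-MS, with a stated time of 1 h, tested at 100 uM (a lower number here means that less of the compound is left, a higher number that more of the compound is left), compound 1 `CC1=C(c2nc(-c3ccc(C#N)cc3)cs2)C(c2ccc(F)nc2)NC(=O)N1` gives 100%, compound 2 `COc1ccc(C2NC(=O)NC(C)=C2c2nc(-c3ccc(C#N)cc3)cs2)cn1` gives 100% and compound 3 `CC1=C(c2nc(-c3ccc(C#N)cc3)cs2)C(c2ccc(O)cc2)NC(=O)N1` gives 100%, so compound 3 stands level with both others. Compound 4 `COc1ccc(C2NC(=O)NC(C)=C2c2nc(-c3ccc(C#N)cc3)cs2)cc1` carries methyl in place of hydrogen on an oxygen on an aromatic ring, turning 4-hydroxyphenyl into 4-methoxyphenyl: methyl in place of hydrogen on an oxygen on an aromatic ring. Among the measured compounds shown here, three measured steps bear on this. Exchanging fluoro for methoxy gives no change at the digits printed from compound 1 to compound 2 (within the scatter). The two exchanges of the aromatic group give no change at the digits printed from compound 1 to compound 3 (within the scatter) and no change at the digits printed from compound 2 to compound 3 (within the scatter). For the measured compounds named here, none of these moves the read-out, and no measured compound shows any loss. No step beyond the scatter is therefore expected in this assay. The expected step is a number 2 percentage points lower from compound 3 to compound 4 (within the scatter). Compound 4 is expected at 98%, with an estimated range of 85% to 100%.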

Compound 4, percent of the compound remaining: 96%
For compound 4 the middle estimate is 2 percentage points above the measured one; measured number inside the range.
By their numbers in this assay, from the lowest: compounds 4, 1, 2 and 3 (each within the scatter of the next).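

In this assay, methyl in place of hydrogen on the oxygen gives a number 4 percentage points lower from compound 3 to compound 4 (within the scatter) and so adds a capped oxygen to the groups that leave the read-out within the scatter. The 4-methoxyphenyl group in place of either pyridine-bearing group gives a number 4 percentage points lower from compound 2 to compound 4 (within the scatter) and a number 4 percentage points lower from compound 1 to compound 4 (within the scatter) and shows no separation from the 6-methoxypyridin-3-yl or 6-fluoropyridin-3-yl compounds. No measurement at hand offers a cause for these small differences.

On these data alone, it remains open whether an amine or a carboxylic acid on this aromatic ring would give a step beyond the scatter. The same holds for a longer chain on the oxygen, such as ethoxy or propoxy.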